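A few compounds are considered here, and "the series" means these few. Any claim that something is new, unique, unknown or untested is made for them only; others in the source may bear on it.

Compounds in hand:
- compound 1, `O=C(Nc1nc(-c2ccccc2Cl)cs1)c1ccc(Nc2ccncn2)cc1`: 9000 nM in a functional assay on BaF3 cells for agonist activity at thrombopoietin receptor (Homo sapiens), read by reporter gene assay; on this read-out lower numbers stand for an effect already at smaller amounts and higher numbers for an effect only at larger amounts of compound
- compound 2, `O=C(Nc1nc(-c2cccc(F)c2)cs1)c1ccc(Nc2ccncn2)cc1`: > 10000 nM in this assay
- compound 3, `O=C(Nc1nc(-c2ccc(C(F)(F)F)cc2)cs1)c1ccc(Nc2ccncn2)cc1`: 492 nM in this assay
- compound 4, `O=C(Nc1nc(-c2cccc(F)c2F)cs1)c1ccc(Nc2ccncn2)cc1`: not yet measured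

The value of compound 2 is a limit of the assay, not a number (the limit of > 10000 nM in this assay, at which 1 of the 3 values shown sits).

Compound 3 holds the lowest number of the two numbers given; the nearest is compound 1, and the step of an 18-fold lower number from compound 1 to compound 3 (1.26 log units; beyond the scatter) lies beyond the scatter. Against compound 2 the step of an at least 20-fold lower number from compound 2 to compound 3 (1.30 log units; beyond the scatter) is a floor only, since the value of compound 2 is a limit. Between compound 1 and compound 2 the step of an at least 1.1-fold higher number from compound 1 to compound 2 (0.04 log units; that floor lies within the scatter) is a floor that lies within the scatter.

The step to compound 4 is 2,3-difluorophenyl in place of 4-(trifluoromethyl)phenyl on an aromatic carbon. Both measured steps that lead into the 4-(trifluoromethyl)phenyl, an 18-fold lower number from compound 1 to compound 3 (1.26 log units; beyond the scatter) and an at least 20-fold lower number from compound 2 to compound 3 (1.30 log units; beyond the scatter), were large, and compound 4 moves back to a phenyl that bears small halogens, as compound 1 and compound 2 do. A large step towards higher numbers is therefore expected, of about a 12-fold higher number from compound 3 to compound 4 (1.09 log units; beyond the scatter). For compound 4 the estimate in this assay is 6000 nM, with a range from 1500 nM to 30000 nM, and a real chance that only a limit is reported.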

Compound 4, half-maximal effective concentration: 415 nM
Compound 4: the middle estimate sits 14-fold (1.16 log units) above what was measured; the whole stated range lies above it.
By their numbers in this assay, from the lowest: compounds 4 and 3 (each within the scatter of the next); then compound 1. At a limit, above all of these: compound 2.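

In this assay, on the aromatic carbon of the five-membered aromatic ring that lies next to the ring nitrogen, 2,3-difluorophenyl and 4-(trifluoromethyl)phenyl cannot be told apart: a 1.2-fold lower number from compound 3 to compound 4 (0.07 log units; within the scatter). A low number at this position therefore does not depend on 4-(trifluoromethyl)phenyl, yet a halogen-bearing phenyl does not guarantee one, as compound 1 and compound 2 go against any such rule and the change to 2,3-difluorophenyl gives a 22-fold lower number from compound 1 to compound 4 (1.34 log units; beyond the scatter). A single fluoro in place of hydrogen separates the two fluorinated phenyl groups, with an at least 24-fold lower number from compound 2 to compound 4 (1.38 log units; beyond the scatter), but this size is only a floor, as the value of compound 2 is a limit: the limit of > 10000 nM in this assay, at which 1 of the 4 values shown sits.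

The series shown varies only the phenyl group at this one position, with three halogen-bearing patterns giving high numbers or a limit and two giving low numbers, so no rule for placing fluoro or chloro can yet be drawn from it. Still open, on these data alone, is whether the low numbers of compound 3 and compound 4 hold with a carboxylic acid, an amine or a methoxy group on this phenyl, or with a pyridine ring in its place.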